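Swapping the Acid-Bearing Ring on a Cyclopropane Core

The source may hold more compounds than are shown below. What is called first, only, known or untested is meant among the compounds shown, and "the series" means these compounds.

Measured compounds:
- Compound 1, `O=C(O)c1cncc(C2CC2c2ccc(OCc3c(-c4c(Cl)cccc4Cl)noc3C3CC3)cc2Cl)c1`: 14 nM
- Compound 2, `CS(=O)(=O)NC(=O)c1ccc(C2CC2c2ccc(OCc3c(-c4c(Cl)cccc4Cl)noc3C3CC3)cc2Cl)cc1`: 44 nM
- Compound 3, `O=C(NCCS(=O)(=O)O)c1ccc(C2CC2c2ccc(OCc3c(-c4c(Cl)cccc4Cl)noc3C3CC3)cc2Cl)cc1`: 1370 nM

These three compounds share one core and differ only in the acidic group attached to it. In an assay on HEK293 cells for agonist activity at Bile acid receptor (Homo sapiens) (a lower number here means that less compound is needed, a higher number that more compound is needed for the effect), compound 1 gives the lowest number of the three; compound 2 sits nearest, and compound 3 stands far above both, so compound 1 is the most potent measured compound here. Within the data shown here, the one step that can be described between neighbouring structures is a 31-fold higher number from compound 2 to compound 3 (1.49 log units; beyond the scatter); it concerns the group on an amide-type nitrogen and does not touch the ring that carries the acid.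

Compound 4, `CC(C)n1nc(C(=O)O)cc1C1CC1c1ccc(OCc2c(-c3c(Cl)cccc3Cl)noc2C2CC2)cc1Cl`, has not been measured. It differs from compound 1 in this way: 3-carboxy-1-isopropyl-1H-pyrazol-5-yl in place of 5-carboxypyridin-3-yl on a saturated ring carbon. Among the measured compounds shown here, no measured step bears directly on this change: the carboxylic acid stays, but the ring that holds it is exchanged, and nothing among the measured compounds shows what such an exchange does. The expectation therefore rests on compound 1 alone, with wide uncertainty, and the step of a 1.8-fold higher number from compound 1 to compound 4 (0.25 log units; within the scatter) is expected to stay small. Compound 4 is estimated at 25 nM, in a range from 7 nM to 90 nM.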

Compound 4, half-maximal effective concentration: 6 nM
Compound 4: the middle estimate sits 4.2-fold (0.62 log units) above what was measured; measured number outside the range, below it.
By their numbers in this assay, from the lowest: compound 4; then compound 1; then compound 2; then compound 3.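

The ring that carries the carboxylic acid on the saturated ring carbon can be exchanged without any loss in this assay: 3-carboxy-1-isopropyl-1H-pyrazol-5-yl in place of 5-carboxypyridin-3-yl gives a 2.3-fold lower number from compound 1 to compound 4 (0.37 log units; beyond the scatter) and makes compound 4 the lowest number of the set. The earlier step concerned only the group on an amide-type nitrogen, whereas this one shows that a five-membered aromatic ring with 2 hetero atoms and an isopropyl group can stand where a six-membered aromatic ring stood. Nothing available explains why the number falls.

As far as these compounds go, the ring and the isopropyl group enter together, so their separate shares in this step remain unknown. From the compounds shown here alone, a methyl group in place of the isopropyl would begin to separate them, and how a methylsulfonyl amide in place of the carboxylic acid would fare on this new ring also remains open.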